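The compounds below may be only part of what the source reports. "The series", "measured", "known", "first", "only" and "open" are said of these compounds alone.

Compound 1 `CS(=O)(=O)Nc1ccc2c(c1)S(=O)(=O)N=C(C1=C(O)[C@@H]3[C@H]4CC[C@H](C4)[C@@H]3N(Cc3ccc(F)c(Cl)c3)C1=O)N2`: in an in vitro ADME assay on microsomes from liver (Homo sapiens) for metabolic stability, tested at 1 uM (on this read-out higher numbers stand for a longer-lived compound and lower numbers for a shorter-lived compound), compound 1 is reported at > 1 h, which is a limit of the assay and not a number.
Compound 2 `CS(=O)(=O)Nc1ccc2c(c1)S(=O)(=O)N=C(C1=C(O)[C@@H]3[C@H]4CC[C@H](C4)[C@@H]3N(Cc3ccc(F)c(F)c3F)C1=O)N2`: in this assay compound 2 is likewise reported at the limit > 1 h.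
Compound 3 `CS(=O)(=O)Nc1ccc2c(c1)S(=O)(=O)N=C(C1=C(O)[C@@H]3[C@@H]4CC[C@@H](C4)[C@@H]3N(Cc3ccc(F)c(Cl)c3)C1=O)N2`: in this assay compound 3 is also reported only as the limit > 1 h.

Compound 4 `CS(=O)(=O)Nc1ccc2c(c1)S(=O)(=O)N=C(C1=C(O)[C@@H]3[C@@H]4CC[C@@H](C4)[C@@H]3N(Cc3ccc(F)c(F)c3F)C1=O)N2` has not been measured in this assay. It differs from compound 3 by 2,3,4-trifluorophenyl in place of 3-chloro-4-fluorophenyl on a saturated chain carbon bound to an amide-type nitrogen in a ring. The same change, (2,3,4-trifluorophenyl in place of 3-chloro-4-fluorophenyl on a saturated chain carbon bound to an amide-type nitrogen in a ring), has already been made between measured compounds, and there it gave a step that the two limits leave unreadable from compound 1 to compound 2; the size cannot be read because of the limit of > 1 h in this assay, at which 3 of the 3 values shown sit. The cores of the two pairs differ as well: compound 3 differs from compound 1 by the two compounds have the same atoms and bonds and differ only in configuration as drawn: 2 of 4 stereo elements differ; a stereocentre at a saturated ring carbon is drawn S in compound 1 and R in compound 3; a stereocentre at a saturated ring carbon is drawn R in compound 1 and S in compound 3, and that difference gave a step that the two limits leave unreadable from compound 1 to compound 3, again unreadable in size because the limit of > 1 h in this assay, at which 3 of the 3 values shown sit, and the fact that compounds 1 and 3 differ only in the configuration as drawn together leave no numbers to compare.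

Set beside that earlier step, the step from compound 3 to compound 4 is expected to be a step that the limit leaves unreadable from compound 3 to compound 4, an expectation that rests on the pattern that (the limit of > 1 h in this assay, at which 3 of the 3 values shown sit). For compound 4 the estimate in this assay is therefore 1.5 h, with a reported limit rather than a number being the most likely outcome.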

Compound 4, half-life: > 1 h
Compound 4 ended at the assay's limit; the forecaster's own chance of this, stated with the estimate: 85%; the middle value is on the limit's open side.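

In this assay, compound 4 ends at the same limit as compounds 1, 2 and 3, and neither the step to compound 4 from compound 3 nor the step to it from compound 2 can be read. The compounds shown leave open how long any of them lasts beyond that limit, and whether the change from 3-chloro-4-fluorobenzyl to 2,3,4-trifluorobenzyl or the difference in configuration alters the half-life at all.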